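Longer acyl chain on the shared glycoside core

The source may report more compounds than this note shows. Statements on the series, on what has been measured and on what is new or still open speak of the compounds shown alone.

Going by the values given here, compound 3 `CCCCCCCC(=O)Nc1nnc(S[C@@H]2O[C@H](CO)[C@H](O)[C@H](O)[C@H]2O)s1` carries the only number in this set: in a functional assay on SK-OV-3 cells (Homo sapiens) for cytotoxicity, read by MTT assay, with a stated time of 24 h (a lower number here means a stronger inhibitor, a higher number a weaker inhibitor), compound 3 gives 56000 nM. Two further entries report no number. Compound 2 `CCCCCCCCCC(=O)Nc1nnc(S[C@@H]2O[C@H](CO)[C@H](O)[C@H](O)[C@H]2O)s1`, which keeps the free sugar but carries a longer saturated acyl chain, gives "not active" (no number reported) in this assay. Compound 1 `CCCCCCCC/C=C\CCCCCCCC(=O)Nc1nnc(S[C@@H]2O[C@H](COC(C)=O)[C@H](OC(C)=O)[C@H](OC(C)=O)[C@H]2OC(C)=O)s1`, with the acetylated sugar and the long unsaturated chain, gives "not active" (no number reported) in this assay. Among the compounds with values here, no step between measured compounds can be computed, so what the numbers show is only this: the single measured value belongs to the shortest chain, and both longer chains return no number at all.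

Compound 4 `CCCCCCCC/C=C\CCCCCCCC(=O)Nc1nnc(S[C@@H]2O[C@H](CO)[C@H](O)[C@H](O)[C@H]2O)s1` differs from compound 3 by dec-1-en-1-yl in place of hydrogen on a saturated chain carbon, seven bonds along the chain from a carbonyl carbon. Because compound 2 with its longer saturated chain gives "not active" (no number reported), and compound 1 with the same unsaturated chain gives "not active" (no number reported), a further lengthening of the chain on compound 3 is expected to go toward weaker inhibition rather than stronger. The step of a 2.3-fold higher number from compound 3 to compound 4 (0.37 log units; beyond the scatter) is therefore expected to be toward a weaker inhibitor, beyond the scatter. Compound 4 is estimated at 130000 nM, within 50000 nM to 350000 nM, with a substantial chance that the assay records no number for compound 4 at all.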

Compound 4, half-maximal inhibitory concentration: "not active" (no number reported)
Compound 4 has no reported number here, and the estimate cannot be compared.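

Going by these compounds alone, compound 4 gives no number in this assay, so no step from compound 3 can be read. Nothing shown here offers an explanation for this result. Still open, on these data alone, is whether any chain longer than that of compound 3 gives a measurable value on the shared core, with either the free or the acetylated sugar.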